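This account rests on a few compounds, and the source may have more. Where it says the series, first, only, none or still open, it means among the compounds named here.

Of the compounds shown here, two have so far been measured in a functional assay on BGC-823 cells (Homo sapiens) for inhibition, read by CCK-8 assay, with a stated time of 48 h; a lower number here means a stronger inhibitor, a higher number a weaker inhibitor. Compound 1 `O=C1CSC(N2N=C(c3ccc(Br)cc3)CC2c2cccc3ccccc23)=N1` gives 14600 nM, and compound 2 `Brc1ccc(C2=NN(C3=NC(c4ccccc4)CS3)C(c3cccc4ccccc34)C2)cc1` gives 17400 nM. Going by the values given here, compound 2 stands at the highest of the two numbers, yet its only neighbour is compound 1, and the step of a 1.2-fold higher number from compound 1 to compound 2 (0.08 log units; within the scatter) lies within the scatter, so the two cannot be told apart. The next compound, compound 3 `c1ccc(C2=NN(C3=NC(c4ccccc4)CS3)C(c3cccc4ccccc34)C2)cc1`, differs from compound 2 in one place: hydrogen in place of bromo on an aromatic carbon. Among the compounds with values here, no measured step touches this change; the single known step concerns a different part of the shared core and is itself within the scatter. There is therefore no ground for expecting a move beyond the scatter in this assay, and the estimated step is a 1.1-fold higher number from compound 2 to compound 3 (0.06 log units; within the scatter). Compound 3 is expected to give about 20000 nM, with a range from 8000 nM to 50000 nM.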

Compound 3, half-maximal inhibitory concentration: 14300 nM
Estimate against measurement, compound 3: 1.4-fold (0.15 log units) above; measured number inside the range.
By their numbers in this assay, from the lowest: compounds 3, 1 and 2 (each within the scatter of the next).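

In this assay, going from 4-bromophenyl to phenyl gives a 1.2-fold lower number from compound 2 to compound 3 (0.09 log units; within the scatter) and so, on this aromatic carbon para to a large group, bromo and hydrogen cannot be told apart. Going by these compounds alone, this is the first measured change at this place, as the earlier step concerned the group on the amine nitrogen in a ring, and it too lies within the scatter. Nothing measured here offers an explanation for this result.

On these data alone, only bromo and hydrogen are compared at this place, so it remains open whether an amine, a carboxylic acid or a longer chain there would move the number beyond the scatter. As far as these compounds go, it also remains open whether any change elsewhere on the shared core would set a compound clearly apart from these three.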